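Methyl in Place of Iodo: Expecting Compound 4

This account rests on a few compounds, and the source may have more. Where it says the series, first, only, none or still open, it means among the compounds named here.

Measured compounds and their values in a functional assay on HUVEC cells (Homo sapiens), read by BrdU incorporation, with a stated time of 72 h; on this read-out lower numbers stand for stronger inhibition and higher numbers for weaker inhibition:
compound 1 `Cc1cccc2cc(/C=C/C(=O)c3ccc(Cl)s3)c(Cl)nc12`: 116 nM
compound 2 `Cc1ccc2nc(Cl)c(/C=C/C(=O)c3ccc(I)s3)cc2c1`: 129 nM
compound 3 `Cc1cccc2cc(/C=C/C(=O)c3ccc(Br)s3)c(Cl)nc12`: 243 nM

Compound 2 stands second highest of the three numbers. Its nearest neighbour is compound 1, whose number is within the scatter of that of compound 2; its furthest is compound 3, and that gap too stays within the scatter, so no order among these three can be claimed except the one measured step, a 2.1-fold higher number from compound 1 to compound 3 (0.32 log units; beyond the scatter), a bromo in place of chloro on an aromatic carbon.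

Compound 4 `Cc1ccc2nc(Cl)c(/C=C/C(=O)c3ccc(C)s3)cc2c1` differs from compound 2 in one place: methyl in place of iodo on an aromatic carbon. Going by the values given here, no measured step swaps a halogen for a methyl, so the only guide is indirect. The step from compound 1 to compound 3 shows that exchanging one group for another on this ring can move the number modestly beyond the scatter, while compound 1 and compound 2, which carry chloro and iodo on the same ring, sit within the scatter of each other. A small step is therefore expected in this assay, if any, with a slight lean towards a higher number. For compound 4 the expected value is 200 nM, with a range from 80 nM to 500 nM, which means an estimated step of a 1.6-fold higher number from compound 2 to compound 4 (0.19 log units; within the scatter).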

Compound 4, half-maximal inhibitory concentration: 128 nM
Compound 4: middle estimate off by 1.6-fold (0.19 log units), on the high side; measured number inside the range.
By their numbers in this assay, from the lowest: compounds 1, 4, 2 and 3 (each within the scatter of the next, the first and the last beyond it).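

In this assay, the change from 5-iodothiophen-2-yl to 5-methylthiophen-2-yl gives a 1.0-fold lower number from compound 2 to compound 4 (0.00 log units; within the scatter) and so leaves the two numbers indistinguishable. Going by these compounds alone, until this pair, only halogens had been seen on this carbon next to the ring sulfur, and the single measured step there, a 2.1-fold higher number from compound 1 to compound 3 (0.32 log units; beyond the scatter) for bromo in place of chloro, was on the core of compound 1; compound 4 now shows that, on the core of compound 2, a halogen at this place is not needed for a number of this size. No measurement shown here accounts for the match between iodo and methyl.

The compounds shown leave open whether a group of another kind at this place, such as an amine, a carboxylic acid or a longer chain like propyl, would keep the number in the same range. They also leave open whether methyl in place of chloro or bromo on the core of compound 1 would give as small a step as the one seen here.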